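A few compounds are considered here, and "the series" means these few. Any claim that something is new, unique, unknown or untested is made for them only; others in the source may bear on it.

The measured compounds:

Compound 1, `C[C@@H](O)[C@H](NC(=O)CN(c1nc(Cl)nc2[nH]cnc12)C1CC1)C(=O)O`: in a functional assay on the whole organism (Tail, strain ICR) with Mus musculus as the target, in the tail flick test, with a stated time of 60 min, at a dose of 25 umol/kg by the oral route (a higher number here means a stronger effect of the compound at the dose given, a lower number a weaker effect), compound 1 gives 30.1%.
Compound 2, `C[C@H](NC(=O)CN(c1nc(Cl)nc2[nH]cnc12)C1CC1)C(=O)O`: in this assay compound 2 gives 44.6%.

Compound 2 stands highest of the two numbers shown; its nearest neighbour is compound 1, and the step of a number 14.5 percentage points higher from compound 1 to compound 2 (beyond the scatter) lies beyond the scatter. Compound 3, `O=C(O)CC[C@H](NC(=O)CN(c1nc(Cl)nc2[nH]cnc12)C1CC1)C(=O)O`, has not yet been measured in this assay. It differs from compound 2 by carboxymethyl in place of hydrogen on a saturated chain carbon, two bonds along the chain from an amide-type nitrogen and a carbonyl carbon. Within the data shown here, the only measured step that bears on this change is the one from compound 1 to compound 2, in which a larger side group gave way to methyl and the number rose by a number 14.5 percentage points higher from compound 1 to compound 2 (beyond the scatter). Among the measured compounds shown here, compound 3 moves the other way, enlarging the side group on the same chain with the carboxymethyl group, so a modest fall is expected rather than a rise, but the present pair offers no direct precedent for a carboxymethyl group. Compound 3 is therefore expected to give about 30% in this assay, within 15% to 47%. This estimate means an expected step of a number 14.6 percentage points lower from compound 2 to compound 3 (beyond the scatter).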

Compound 3, a percentage reported as activity, at one dose (the size of the read-out at that dose, not a potency): 33.3%
For compound 3 the middle estimate is 3.3 percentage points below the measured one, and the stated range covers the measured number.
By their numbers in this assay, from the lowest: compounds 1 and 3 (each within the scatter of the next); then compound 2.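

In this assay, lengthening the methyl of compound 2 to 2-carboxyethyl gives a number 11.3 percentage points lower from compound 2 to compound 3 (beyond the scatter) and so repeats, with a second and different side group, the result seen with 1-hydroxyethyl. Methyl on this saturated chain carbon thus stands beyond the scatter of both other side groups, while these two cannot be told apart, with a number 3.2 percentage points higher from compound 1 to compound 3 (within the scatter) as the step between them. Nothing available accounts for these differences in the read-out.

The three compounds leave open whether the read-out at this position depends on the size of the side group or on its oxygen-bearing ends, since none carries a plain ethyl or a longer hydrocarbon chain. Going by these compounds, it is also open what an amine at the end of the side chain, or hydrogen in place of methyl, would give.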